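Methyl for Methoxy Next to a Benzothiazole Amide

The compounds below may be only part of what the source reports. "The series", "measured", "known", "first", "only" and "open" are said of these compounds alone.

The measured compounds:
compound 1, `COc1ccc(-c2nc3ccccc3s2)cc1NC(=O)c1cc([N+](=O)[O-])ccc1Cl`, in an ADME assay for permeability, using PAMPA, at pH 7.4 (a higher number here means that the compound crosses the layer faster, a lower number that the compound crosses the layer more slowly), compound 1 gives "below limit of detection" (no number reported), which is no number.
compound 2, `COc1ccc(-c2nc3ccccc3o2)cc1NC(=O)c1cc([N+](=O)[O-])ccc1Cl`, in this assay compound 2 gives 274 10^-6 cm/s.
compound 3, `COC(=O)C1CCN(c2cc(Cl)c(C(=O)Nc3cc(-c4nc5ccccc5s4)ccc3OC)cc2[N+](=O)[O-])CC1`, in this assay compound 3 gives < 1 10^-6 cm/s, a limit and not a number.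

Compound 1 stands without a single number in this assay; what it gives is no number at all, and the set holds one limit, (the limit of < 1 10^-6 cm/s in this assay, at which 1 of the 3 values shown sits), so two of the three results are without a number and only compound 2 carries one.

Compound 4 is `Cc1ccc(-c2nc3ccccc3s2)cc1NC(=O)c1cc([N+](=O)[O-])ccc1Cl`. It differs from compound 1 in one place: methyl in place of methoxy on an aromatic carbon.

Among the measured compounds shown here, no step between measured compounds is available for this change, so its size in this assay is not known from these data. For the measured compounds named here, compound 1 gives no number at all, and the one numbered value in the set belongs to compound 2, which carries a different core. Compound 4 is expected to stay low, with a fair chance of another result without a number rather than a number.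

Compound 4 is estimated to give about 4 10^-6 cm/s in this assay, within a range from 0.5 10^-6 cm/s to 60 10^-6 cm/s.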

Compound 4, apparent permeability: 41 10^-6 cm/s
Estimate against measurement, compound 4: 10-fold (1.01 log units) below, and the stated range covers the measured number.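

In this assay compound 1 gives "below limit of detection" (no number reported) and so offers no number to set against compound 4, which means no step can be read between the two. The compounds shown leave open how far methyl in place of methoxy moves the read-out on this core, and nothing given here bears on the result for compound 4.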